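A few compounds are considered here, and "the series" means these few. Any claim that something is new, unique, unknown or untested is made for them only; others in the source may bear on it.

Going by the values given here, in an ADME assay on TZM cells (Homo sapiens) for cytotoxicity, read by XTT assay, with a stated time of 4 days (on this read-out lower numbers stand for higher toxicity in this test and higher numbers for lower toxicity in this test), compound 2 `Cc1cc(CO)cc(C)c1Oc1cc(Nc2ccc(C#N)cc2)c(N)cc1CO` gives 15900 nM, the only exact number so far. Compound 1 `CNC(=O)c1cc2ncn(-c3ccc(C#N)cc3)c2cc1Oc1c(C)cc(/C=C/C#N)cc1C` reads > 890000 nM, which is a limit. Compound 3 `Cc1cc(CCC#N)cc(C)c1Oc1cc(Nc2ccc(C#N)cc2)c(N)cc1C(F)(F)F` reads > 7100 nM, which is also a limit. Compound 4 `Cc1cc(/C=C/C#N)cc(C)c1Oc1cc(Nc2ccc(C#N)cc2)c(N)cc1CO` is not yet measured. It has 2-cyanoethenyl in place of hydroxymethyl on an aromatic carbon, meta to two methyl groups and para to a large group: 2-cyanoethenyl in place of hydroxymethyl on an aromatic carbon. Among the compounds with values here, no measured pair isolates this change, so the expectation in this assay is weakly grounded: no shift beyond the scatter, in either direction. The estimated step is a 1.1-fold lower number from compound 2 to compound 4 (0.06 log units; within the scatter). For compound 4 the expected value is 14000 nM, with an estimated range of 4000 nM to 50000 nM.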

Compound 4, half-maximal cytotoxic concentration: 16300 nM
The estimate for compound 4 lay 1.2-fold (0.07 log units) below the measured number, and the stated range covers the measured number.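

In this assay, going by these compounds alone, the first exact pair at the aromatic carbon meta to two methyl groups gives a 1.0-fold higher number from compound 2 to compound 4 (0.01 log units; within the scatter), so 2-cyanoethenyl and hydroxymethyl are not told apart at this position on this core. Compounds 1 and 3 differ from compound 2 in more than one place and could not show this. Nothing available bears on why the change leaves the number within the scatter.

Open, on these data alone, is whether an amine, a carboxylic acid or a longer chain at this carbon would also stay within the scatter.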